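The source may hold more compounds than are shown below. What is called first, only, known or untested is meant among the compounds shown, and "the series" means these compounds.

Measured so far:
- Compound 1 `CCCCCCn1cnc2c(Nc3ccc(O)cc3)nc(N[C@H]3CC[C@H](N)CC3)nc21`: 190 nM
- Compound 2 `CC(C)CCn1cnc2c(Nc3cccc(O)c3)nc(N[C@H]3CC[C@H](N)CC3)nc21`: 60 nM
- Compound 3 `COc1ccc(Nc2nc(N[C@H]3CC[C@H](N)CC3)nc3c2ncn3CCC(C)C)c(OC)c1`: 630 nM

These three share a core and were tested in a functional assay on EOL1 cells (Homo sapiens) for inhibition, read by fluorescence, with a stated time of 72 h; a lower number here means a stronger inhibitor of growth, a higher number a weaker inhibitor of growth. Among them compound 3 stands highest, with compound 1 nearest and compound 2 furthest away. Compound 4 `CC(C)CCn1cnc2c(Nc3ccc(O)cc3)nc(N[C@H]3CC[C@H](N)CC3)nc21` is the compound not yet measured. It differs from compound 3 in one place: 4-hydroxyphenyl in place of 2,4-dimethoxyphenyl on a nitrogen on an aromatic ring. Within the data shown here, the one measured step that bears on this is an 11-fold higher number from compound 2 to compound 3 (1.02 log units; beyond the scatter), which replaced a hydroxyphenyl by the dimethoxyphenyl and moved the number up by a large amount. Compound 4 undoes that kind of change, though with the hydroxyl in a different spot, and compound 1 shows a 4-hydroxyphenyl giving a number well below that of compound 3. A large step down is therefore expected in this assay, a 6.3-fold lower number from compound 3 to compound 4 (0.80 log units; beyond the scatter), and compound 4 is estimated at 100 nM, between 40 nM and 300 nM.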

Compound 4, concentration for 50% growth inhibition: 30 nM
Compound 4: middle estimate off by 3.3-fold (0.52 log units), on the high side; the whole stated range lies above it.
By their numbers in this assay, from the lowest: compounds 4 and 2 (each within the scatter of the next); then compound 1; then compound 3.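

In this assay, 4-hydroxyphenyl in place of 2,4-dimethoxyphenyl gives a 21-fold lower number from compound 3 to compound 4 (1.32 log units; beyond the scatter), so the group on this nitrogen strongly affects growth inhibition. Swapping 3-hydroxyphenyl for 4-hydroxyphenyl gives a 2.0-fold lower number from compound 2 to compound 4 (0.30 log units; within the scatter), so these two groups cannot be told apart here. With 4-hydroxyphenyl held constant, isopropyl in place of butyl on a saturated chain carbon gives a 6.3-fold lower number from compound 1 to compound 4 (0.80 log units; beyond the scatter), showing that the chain matters too, though nothing shown explains any of these steps.

From the compounds shown here alone, whether the hydroxyl group itself is needed remains open. Plain phenyl, 4-methoxyphenyl or 4-aminophenyl on this nitrogen would help to answer that.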